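The compounds below may be only part of what the source reports. "The series", "measured", "known", "first", "only" and "open" are said of these compounds alone.

Measured so far in a physicochemical assay for lipophilicity, using the shake flask method, in phosphate buffer, measured as octanol-water partition, with a stated time of 30 min, at pH 7.4; a lower number here means a more polar compound, a higher number a more lipophilic compound:
- compound 1 `CN(C)C(=O)c1cc(-c2cnc(NCc3c(F)ccc4c3CCO4)c3cn[nH]c(=O)c23)n(C)n1` gives 2.1
- compound 2 `Cc1ncccc1-c1cnc(NCc2c(F)ccc3c2CCO3)c2cn[nH]c(=O)c12` gives 3

Compound 2 holds the higher of the two numbers, at 3 so far. Compound 3 `CNC(=O)c1cc(-c2cnc(NCc3c(F)ccc4c3CCO4)c3cn[nH]c(=O)c23)n(C)n1` is unmeasured. The change to it is 1-methyl-3-(methylcarbamoyl)-1H-pyrazol-5-yl in place of 2-methylpyridin-3-yl on an aromatic carbon. Within the data shown here, the one measured step that bears on this is a number 0.90 log units higher from compound 1 to compound 2 (beyond the scatter) and it exchanged a close relative of the entering group, 3-(dimethylcarbamoyl)-1-methyl-1H-pyrazol-5-yl, for 2-methylpyridin-3-yl. Run in reverse, that step points downward, so a drop of similar size is expected, estimated as a number 1.10 log units lower from compound 2 to compound 3 (beyond the scatter) here. In this assay compound 3 is expected at 1.9 (estimated range 1.5 to 2.3).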

Compound 3, distribution coefficient: 2.1
The estimate for compound 3 lay 0.20 log units below the measured number; low and high end bracket the measured number.
By their numbers in this assay, from the lowest: compounds 1 and 3 (each within the scatter of the next); then compound 2.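

In this assay, 1-methyl-3-(methylcarbamoyl)-1H-pyrazol-5-yl in place of 2-methylpyridin-3-yl on this aromatic carbon gives a number 0.90 log units lower from compound 2 to compound 3 (beyond the scatter), so a pyrazole amide with the amide hydrogen sits with its dimethyl relative on the same side of the pyridine. Hydrogen in place of methyl on the amide-type nitrogen gives no change at the digits printed from compound 1 to compound 3 (within the scatter), so the two amides cannot be told apart here. Nothing available explains either step. Still open, from the compounds shown here alone, is how a carboxylic acid, an amine or a longer chain on the pyrazole would read in this assay.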